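From phenyl to chloro on a shared core

A few compounds are considered here, and "the series" means these few. Any claim that something is new, unique, unknown or untested is made for them only; others in the source may bear on it.

In a functional assay on KG-1 cells (Homo sapiens) for cytotoxicity, read by luminescence and CellTiter-Glo, with a stated time of 3 days (on this read-out higher numbers stand for weaker inhibition and lower numbers for stronger inhibition), compound 1 (`N#Cc1ccc(NC(=O)c2cc(-c3ccccc3)ccc2O)cc1`) gives 1300 nM and stands level, within the scatter, with compound 3 (`O=C(Nc1ccc([N+](=O)[O-])cc1)c1cc(F)ccc1O`) at 1100 nM on the same read-out. Compound 2 (`N#Cc1ccc(NC(=O)c2ccc3ccccc3c2O)cc1`) gives 2720 nM as a higher number than compound 1, beyond the scatter, which makes it the weaker of that pair.

Compound 4 (`N#Cc1ccc(NC(=O)c2cc(Cl)ccc2O)cc1`) has not been measured yet. It differs from compound 1 by a single swap, chloro in place of phenyl on an aromatic carbon para to a hydroxy group. Going by the values given here, no measured pair shows this swap alone. Compound 3 also has no phenyl there, although it differs elsewhere too, and its 1100 nM lies within the scatter of compound 1. No step beyond the scatter is therefore expected in this assay in either direction. The estimated change is small, a 1.1-fold lower number from compound 1 to compound 4 (0.03 log units; within the scatter) in size. For compound 4 the estimated value is 1200 nM with an expected range from 450 nM to 3200 nM in repeat measurements.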

Compound 4, half-maximal inhibitory concentration: 1860 nM
Estimate against measurement, compound 4: 1.6-fold (0.19 log units) below; measured number inside the range.
By their numbers in this assay, from the lowest: compounds 3, 1, 4 and 2 (each within the scatter of the next, the first and the last beyond it).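

In this assay the swap of phenyl for chloro on this aromatic carbon, para to a hydroxy group, gives a 1.4-fold higher number from compound 1 to compound 4 (0.16 log units; within the scatter) and so leaves the two compounds level. Going by these compounds alone, this is the first direct reading of that change alone: a group of six heavy atoms with its own ring gives way to a single chlorine, and the read-out shows no step beyond the scatter. No measurement shown here explains why the two compounds stand level.

From the compounds shown here alone, whether an amine, a methoxy group or a carboxylic acid at this place would also stay level remains open. So does whether the same swap would give a similar step on a different core, since this single pair speaks only for the core of compound 1.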